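Side-chain variation on the shared core: stability notes

The compounds below may be only part of what the source reports. "The series", "measured", "known", "first", "only" and "open" are said of these compounds alone.

Three compounds share one core and differ only in the chain on the nitrogen on an aromatic ring: compound 1 `OCCCNc1nnc(-c2ccc(F)c(F)c2Nc2ccc(I)cc2F)o1`, compound 2 `OCCCCNc1nnc(-c2ccc(F)c(F)c2Nc2ccc(I)cc2F)o1` and compound 3 `CNCCNc1nnc(-c2ccc(F)c(F)c2Nc2ccc(I)cc2F)o1`. In an in vitro ADME assay on microsomes from liver (Homo sapiens) for metabolic stability (a higher number here means that the compound lasts longer, a lower number that the compound disappears faster), compound 1 gives 0.667 h, compound 2 gives 0.667 h and compound 3 gives 0.667 h. The steps of no change at the digits printed from compound 1 to compound 2 (within the scatter), no change at the digits printed from compound 1 to compound 3 (within the scatter) and no change at the digits printed from compound 2 to compound 3 (within the scatter) all stay within the scatter, so compound 3 stands level with compounds 1 and 2. Compound 4 `OCCCCCNc1nnc(-c2ccc(F)c(F)c2Nc2ccc(I)cc2F)o1` extends the series by 3-hydroxypropyl in place of methylamino on a saturated chain carbon, two bonds along the chain from a nitrogen on an aromatic ring. Because the step of no change at the digits printed from compound 1 to compound 2 (within the scatter) showed nothing on lengthening the hydroxy-bearing chain and the step of no change at the digits printed from compound 2 to compound 3 (within the scatter) nothing on exchanging chain ends, no movement beyond the scatter is expected. The step expected from compound 3 to compound 4 is no change at the digits printed from compound 3 to compound 4 (within the scatter). Compound 4 is estimated at 0.667 h, range 0.35 h to 1.3 h.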

Compound 4, half-life: 0.667 h
Compound 4: middle estimate and measured number agree at the digits printed, within the range that was stated.
By their numbers in this assay, from the lowest: compounds 1, 2, 3 and 4 (each within the scatter of the next).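

In this assay, 3-hydroxypropyl in place of methylamino on a saturated chain carbon, two bonds along the chain from a nitrogen on an aromatic ring, gives no change at the digits printed from compound 3 to compound 4 (within the scatter). The 5-hydroxypentyl chain also stays level with the shorter hydroxy-bearing chains, with no change at the digits printed from compound 2 to compound 4 (within the scatter) and no change at the digits printed from compound 1 to compound 4 (within the scatter), so the hydroxy-bearing chains shown do not separate at any of these lengths. Nothing at hand accounts for this flat result. On these data alone, whether a carboxylic acid or a morpholine at the chain end would separate from this level remains open. So does the outcome for a chain longer than 5-hydroxypentyl.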